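From compound 2 to compound 3: a tert-butoxycarbonyl step

The compounds below may be only part of what the source reports. "The series", "measured", "known", "first", "only" and "open" are said of these compounds alone.

Measured in an ADME assay on MCF7-DOX cells (Homo sapiens) for cytotoxicity, read by MTT assay, with a stated time of 48 h; a higher number here means a weaker inhibitor, a lower number a stronger inhibitor:
- compound 1 `COc1cc(O)c(C(=O)/C=C/c2cccc(N3CCNCC3)c2)c(OC)c1`: 99200 nM
- compound 2 `COc1cc(OC)c(C(=O)/C=C/c2cccc(N3CCNCC3)c2)c(O)c1CC=C(C)C`: 99900 nM

On these numbers, compound 2 stands within the scatter of compound 1. Among the compounds with values here, the only measured step is a 1.0-fold higher number from compound 1 to compound 2 (0.00 log units; within the scatter), and it comes with 3-methylbut-2-en-1-yl in place of hydrogen on an aromatic carbon.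

Compound 3 `COc1cc(OC)c(C(=O)/C=C/c2cccc(N3CCN(C(=O)OC(C)(C)C)CC3)c2)c(O)c1CC=C(C)C` differs from compound 2 in one place: tert-butoxycarbonyl in place of hydrogen on an amine nitrogen in a ring. This puts tert-butoxycarbonyl in place of hydrogen on an amine nitrogen in a ring. Within the data shown here, the measured step lies at another place, so it gives no size for this change, and no measured step touches that nitrogen. In this assay, no step beyond the scatter is therefore expected, though with little certainty. The expected step is a 1.2-fold lower number from compound 2 to compound 3 (0.10 log units; within the scatter). Compound 3 is estimated at 80000 nM, with an expected range of 25000 nM to 130000 nM.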

Compound 3, half-maximal inhibitory concentration: 42600 nM
For compound 3 the middle estimate is 1.9-fold (0.27 log units) above the measured one; the range from low to high includes it.
By their numbers in this assay, from the lowest: compound 3; then compounds 1 and 2 (each within the scatter of the next).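

In this assay the amine nitrogen of the six-membered ring proves to be a place where a change can be read: tert-butoxycarbonyl in place of hydrogen gives a 2.3-fold lower number from compound 2 to compound 3 (0.37 log units; beyond the scatter) and so separates itself from the scatter, unlike the step on an aromatic carbon, which is a 1.0-fold higher number from compound 1 to compound 2 (0.00 log units; within the scatter) and stays within it. The step at the nitrogen is modest, yet it shows that the hydrogen on that nitrogen is not needed for the cytotoxicity read here. Nothing at hand bears on why the number moved.

From the compounds shown here alone, it remains open whether the step belongs to the carbonyl or to the tert-butyl part, and whether an acetyl group, a methyl group or a longer chain on that nitrogen would give a similar step. Going by these compounds, it is also open whether tert-butoxycarbonyl would give the same step on the core of compound 1, which lacks the 3-methylbut-2-en-1-yl group.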